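From a sulfonamide to a sulfone on the shared core

A few compounds are considered here, and "the series" means these few. Any claim that something is new, unique, unknown or untested is made for them only; others in the source may bear on it.

Among the compounds with values here, compound 1 `Cc1ccc(S(=O)(=O)NC(C)C)cc1C#Cc1cc(Cl)ccc1OCC(=O)O` is one of two compounds measured in an assay on CHO cells for displacement of a labelled ligand from prostaglandin D2 receptor 2 (Homo sapiens), read by scintillation counting; a higher number here means a weaker inhibitor, a lower number a stronger inhibitor. There compound 1 gives 3.4 nM, the lowest of the two numbers. The other measured compound, compound 2 `N#Cc1ccc(OCC(=O)O)c(C#Cc2ccccc2Cl)c1`, gives 24 nM in this assay, a number that lies well beyond the scatter from that of compound 1; the two structures differ in more than one place, so this gap says nothing about any single change.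

Compound 3 `Cc1ccc(S(=O)(=O)CC(C)C)cc1C#Cc1cc(Cl)ccc1OCC(=O)O` differs from compound 1 in one place: isobutyl in place of isopropylamino on a sulfonyl sulfur. The group that leaves and the group that enters are of the same size, but the isopropylamino group brings a hydrogen-bond donor and the isobutyl group brings none. Within the data shown here, no measured pair shows this change, so its direction is uncertain. A small step in this assay, most likely towards a higher number, or none beyond the scatter, is expected; the estimated step is a 1.8-fold higher number from compound 1 to compound 3 (0.25 log units; within the scatter). Compound 3 is therefore expected to give about 6 nM in this assay, within a range from 1.5 nM to 25 nM.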

Compound 3, inhibition constant: 3 nM
Compound 3: the middle estimate sits 2.0-fold (0.30 log units) above what was measured; the range from low to high includes it.
By their numbers in this assay, from the lowest: compounds 3 and 1 (each within the scatter of the next); then compound 2.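

Within the data shown here, the step from isopropylamino to isobutyl on a sulfonyl sulfur is the first change in a single place that can be read in this assay, and it comes to a 1.1-fold lower number from compound 1 to compound 3 (0.05 log units; within the scatter) in this series. On the shared core, then, the nitrogen of the isopropylamino group and its hydrogen-bond donor can give way to the all-carbon isobutyl group, which has no such donor, without a difference that can be told from the scatter. No measurement shown here explains why the two groups give numbers this close.

This single pair says nothing yet about how much room there is on the sulfonyl sulfur, since a methyl group, a longer chain, a primary amine or a carboxylic acid at this place could each give a quite different number in this assay. It also leaves open whether isobutyl and isopropylamino would stay this close if the chlorine or the methyl group on the shared core were replaced by other groups.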